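Ortho substituent swap on the thiourea phenyl ring

This account rests on a few compounds, and the source may have more. Where it says the series, first, only, none or still open, it means among the compounds named here.

Measured so far:
compound 1 `O=C(NC(=S)Nc1ccccc1)Nc1ccc2c(c1)C(=O)C(=O)N2Cc1ccccc1` gives 2.48 in a physicochemical assay for lipophilicity, in phosphate buffer, measured as octanol-water partition; a higher number here means a more lipophilic compound, a lower number a more polar compound;
compound 2 `O=C(NC(=S)Nc1ccccc1Cl)Nc1ccc2c(c1)C(=O)C(=O)N2Cc1ccccc1` gives 3.01 in this assay.

Compound 2 stands highest of the two numbers; its nearest neighbour is compound 1, with the step of a number 0.53 log units higher from compound 1 to compound 2 (beyond the scatter). Compound 3 `Cc1ccccc1NC(=S)NC(=O)Nc1ccc2c(c1)C(=O)C(=O)N2Cc1ccccc1` is not yet measured. It differs from compound 2 by methyl in place of chloro on an aromatic carbon. Going by the values given here, the only measured step that bears on this is the one from compound 1 to compound 2, which added chloro for hydrogen. Methyl in place of chloro trades one lipophilic group for another, so the step of a number 0.16 log units lower from compound 2 to compound 3 (within the scatter) is expected to stay within the scatter, if anything slightly downward. Compound 3 is estimated at 2.85, within 2.45 to 3.25.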

Compound 3, partition coefficient: 2.98
Compound 3: middle estimate off by 0.13 log units, on the low side; the range from low to high includes it.
By their numbers in this assay, from the lowest: compound 1; then compounds 3 and 2 (each within the scatter of the next).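

In this assay, methyl and chloro on this aromatic carbon cannot be told apart, with a number 0.03 log units lower from compound 2 to compound 3 (within the scatter), while methyl in place of hydrogen gives a number 0.50 log units higher from compound 1 to compound 3 (beyond the scatter). Among these three, the read-out separates compound 1 from the two substituted compounds, but not compound 2 from compound 3. Nothing available explains this result.

From the compounds shown here alone, whether an amine, a carboxylic acid or a longer chain such as propyl on this carbon would fall with or apart from methyl and chloro remains open. So does whether methyl and chloro also match on other carbons of this ring.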